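The source may report more compounds than this note shows. Statements on the series, on what has been measured and on what is new or still open speak of the compounds shown alone.

Compound 2 `CCCN(CC1CC1)c1nc(C)nc2c1n(C)c(=O)n2-c1c(C)cc(C)nc1C` carries the shared core with a (cyclopropylmethyl)(propyl)amino group on an aromatic carbon. In an assay on HEK293 cells for binding affinity to corticotropin-releasing factor receptor 1 (Homo sapiens), read by radioligand binding (on this read-out lower numbers stand for stronger inhibition and higher numbers for weaker inhibition), compound 2 gives 113 nM. Compound 1 `CCCCN(CC)c1nc(C)nc2c1n(C)c(=O)n2-c1c(C)cc(C)nc1C` bears butyl(ethyl)amino at that position, and in this assay compound 1 gives 124 nM; the step of a 1.1-fold lower number from compound 1 to compound 2 (0.04 log units; within the scatter) is within the scatter, so these two compounds cannot be ranked on the numbers at hand. Compound 3 `CCCN(CCC)c1nc(C)nc2c1n(C)c(=O)n2-c1c(C)cc(C)nc1C` is reached from compound 2 by the change (ethyl in place of cyclopropyl on a saturated chain carbon bound to a nitrogen on an aromatic ring). Among the compounds with values here, the only measured step that bears on an exchange at this amino substituent is the one from compound 1 to compound 2, and it showed no movement beyond the scatter. On that basis compound 3 is expected to stay close to compound 2, with the step of a 1.2-fold higher number from compound 2 to compound 3 (0.09 log units; within the scatter) estimated to remain within the scatter. The estimate for compound 3 in this assay is therefore 140 nM, with a range from 60 nM to 330 nM.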

Compound 3, inhibition constant: 259 nM
Estimate against measurement, compound 3: 1.9-fold (0.27 log units) below; the measured number falls inside the stated range.
By their numbers in this assay, from the lowest: compounds 2 and 1 (each within the scatter of the next); then compound 3.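

In this assay, this amino substituent proves sensitive to exchange, as opening the cyclopropyl group to ethyl gives a 2.3-fold higher number from compound 2 to compound 3 (0.36 log units; beyond the scatter), a modest step that the earlier within-scatter comparison did not foreshadow. Dipropylamino also separates from butyl(ethyl)amino, with a 2.1-fold higher number from compound 1 to compound 3 (0.32 log units; beyond the scatter), so compound 3 is the weakest of the three, while compound 1 and compound 2 remain unranked. The data at hand offer no measurement that would explain this difference.

The compounds shown leave open whether the gain of compound 2 over compound 3 is specific to cyclopropylmethyl or would also appear with a cyclobutylmethyl group. They also do not show how a methoxyethyl chain would fare at this position, or whether replacing the propyl group that compound 2 and compound 3 share would change the picture.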